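The source may report more compounds than this note shows. Statements on the series, on what has been measured and on what is new or still open speak of the compounds shown alone.

Of the compounds shown here, three have numbers so far. Compound 1 `Nc1ccccc1NC(=O)/C=C/c1ccc(Cn2cnc3c(Nc4cccc(Cl)c4)nc(Cl)nc32)cc1` gives 35.8% in a functional assay on HepG2 cells (Homo sapiens) for antiproliferative activity, read by CCK-8 assay, with a stated time of 72 h, tested at 2 uM; on this read-out lower numbers stand for a weaker effect and higher numbers for a stronger effect at the one concentration tested. Compound 2 `Nc1ccccc1NC(=O)/C=C/c1ccc(Cn2cnc3c(Nc4ccccc4)nc(Cl)nc32)cc1` gives 16.4% in this assay, the change being a number 19.4 percentage points lower from compound 1 to compound 2 (beyond the scatter). Compound 3 `Nc1ccccc1NC(=O)c1ccc(Cn2cnc3c(Nc4ccccc4)nc(Cl)nc32)cc1` gives 49.6% in this assay, with a number 33.2 percentage points higher from compound 2 to compound 3 (beyond the scatter). Compound 3 thus stands highest of the three, beyond the scatter from both compound 1 and compound 2.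

The next member is compound 4 `Nc1ccccc1NC(=O)c1ccc(Cn2cnc3c(Nc4cccc(OC(F)(F)F)c4)nc(Cl)nc32)cc1`. From compound 3 it differs by trifluoromethoxy in place of hydrogen on an aromatic carbon. Among the measured compounds shown here, the one measured step that bears on this is the one from compound 1 to compound 2, where a chloro left the same aromatic carbon and the number fell by a modest amount, beyond the scatter. A group entering at that carbon of compound 3 is therefore expected to move the number upward by a step of similar size, a number 12.4 percentage points higher from compound 3 to compound 4 (beyond the scatter). For the measured compounds named here, no measured pair shows a trifluoromethoxy, so the size rests on one step only. For compound 4 the expected value in this assay is 62%, within a range from 45% to 80%.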

Compound 4, a percentage reported as inhibition, at one concentration (the size of the read-out at that concentration, not a potency): 1.88%
The estimate for compound 4 lay 60.1 percentage points above the measured number, and the stated range ends above it.
By their numbers in this assay, from the lowest: compound 4; then compound 2; then compound 1; then compound 3.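

Trifluoromethoxy at this carbon gives a number 47.7 percentage points lower from compound 3 to compound 4 (beyond the scatter) in this assay, so a group entering here does not have to raise the number. The earlier pair with the ethenyl linker pointed the other way, with a number 19.4 percentage points lower from compound 1 to compound 2 (beyond the scatter) when chloro gave way to hydrogen, so the direction of a change at this carbon is not constant across the two changes shown. Nothing at hand accounts for the difference between these two steps.

The compounds shown leave open whether the loss follows trifluoromethoxy alone or any group at this carbon of compound 3, which chloro, methoxy or an amine there would help to separate. Trifluoromethoxy on the ethenyl-linked compound 2 would show whether the linker decides the direction.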